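Shortening the acyl chain: compound 2 to compound 3

The source may report more compounds than this note shows. Statements on the series, on what has been measured and on what is new or still open speak of the compounds shown alone.

Measured so far in a functional assay on KYSE-450 cells (Homo sapiens) for inhibition, read by MTT assay, with a stated time of 48 h; on this read-out lower numbers stand for stronger inhibition and higher numbers for weaker inhibition:
- compound 1 `COc1ccc(CNc2cc(OC)c(OC)c(OC)c2)cc1[N+](=O)[O-]` gives 16800 nM
- compound 2 `CCCCC(=O)N(Cc1ccc(OC)c(O)c1)c1cc(OC)c(OC)c(OC)c1` gives 300 nM

Of these two numbers, the lower belongs to compound 2 at 300 nM, and the higher belongs to compound 1 at 16800 nM, a gap that lies beyond the scatter. The two compounds differ in more than one place, so their gap says nothing about any single change.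

Still unmeasured is compound 3 `COc1ccc(CN(C(C)=O)c2cc(OC)c(OC)c(OC)c2)cc1O`. Its structure departs from compound 2 by hydrogen in place of propyl on a saturated chain carbon bound to a carbonyl carbon, which, cut one bond further out, reads butylcarbonyl to acetyl. Among the compounds with values here, no measured pair isolates this change, so the expectation here is a judgement and not a read-across from a known step. In this assay no step beyond the scatter is expected, with a slight lean towards a lower number. The estimate is a 1.5-fold lower number from compound 2 to compound 3 (0.18 log units; within the scatter). Compound 3 is expected at about 200 nM, with an estimated range of 50 nM to 900 nM.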

Compound 3, half-maximal inhibitory concentration: 160 nM
Compound 3: the middle estimate sits 1.3-fold (0.10 log units) above what was measured; measured number inside the range.
By their numbers in this assay, from the lowest: compounds 3 and 2 (each within the scatter of the next); then compound 1.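

Within the data shown here, this is the first pair that differs in one place. In this assay, replacing butylcarbonyl with acetyl gives a 1.9-fold lower number from compound 2 to compound 3 (0.27 log units; within the scatter), so hydrogen can take the place of propyl on a saturated chain carbon bound to a carbonyl carbon without a step beyond the scatter. Between these two chain lengths the read-out shows no separation, and the propyl part of the chain is not needed for a number at this level in this pair of compounds. No measurement at hand gives a reason for this outcome.

Open, on these data alone, is whether the flat result holds beyond these two chains: a longer chain, a branched chain such as isopropyl, a cyclopropyl group, or a chain ending in an amine or a carboxylic acid could each behave differently at this place. Also open is what the acyl group itself contributes, since compound 1 differs from compound 2 and compound 3 in more than one place and a direct comparison with the matching unacylated amine is not available among the compounds shown.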